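Methyl to Methoxy on a Non-Toxic Compound

The compounds below may be only part of what the source reports. "The series", "measured", "known", "first", "only" and "open" are said of these compounds alone.

In an ADME assay on cells (spleen, Mus musculus, strain C57BL/6) for inhibition, read by flow cytometry and propidium iodide staining, with a stated time of 24 h, at 37 degrees C (on this read-out lower numbers stand for an effect already at smaller amounts and higher numbers for an effect only at larger amounts of compound), compound 1 (`O=C(Cn1cc(C(=O)O)nn1)NCc1ccccc1`) gives "non-toxic" (no number reported), with no number reported. For the measured compounds named here, compound 2 (`O=C(O)CCc1cn(CC(=O)NCc2ccccc2)nn1`) gives 1420 uM, the only number in this small set and the sole numerical guide for what follows. Compound 3 (`Cc1ccc(-c2cn(CC(=O)NCc3ccccc3)nn2)cc1`) gives "non-toxic" (no number reported), so it has no single number and shares its standing with compound 1. Compound 4 (`COc1ccc(-c2cn(CC(=O)NCc3ccccc3)nn2)cc1`) differs from compound 3 by methoxy in place of methyl on an aromatic carbon, para to a large group: methoxy in place of methyl on an aromatic carbon. Going by the values given here, no measured pair shows the effect of this change, so no step beyond the usual scatter is expected in this assay, and no direction can be given. Compound 4 is expected near 1400 uM, with an estimated range from 400 uM to 4000 uM.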

Compound 4, concentration for half-maximal effect: "non-toxic" (no number reported)
Nothing numeric was reported for compound 4, and the estimate cannot be compared.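

Compound 3 and compound 4 are both reported only as non-toxic, without a number, so no step can be read between them, and no supporting evidence bears on this result. On these data alone, whether methoxy in place of methyl shifts the read-out at all stays open.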